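Flipping One Stereocentre in Compound 2

The compounds below may be only part of what the source reports. "The series", "measured", "known", "first", "only" and "open" are said of these compounds alone.

In a functional assay on HCT-116 cells (Homo sapiens) for inhibition, read by MTT assay, with a stated time of 72 h (on this read-out lower numbers stand for stronger inhibition and higher numbers for weaker inhibition), compound 1 (`CC1=NN(c2ccccc2)C(=O)[C@@]12C(=O)C=CC[C@H]2c1ccc(C)cc1`) gives 5210 nM and compound 2 (`CC1=NN(c2ccccc2)C(=O)[C@]12C(=O)C=CC[C@H]2c1cccc(C)c1`) gives 9580 nM as its reading, so the two values lie within the usual scatter of each other. Within the data shown here, compound 2 therefore stands level with the only other measured compound. Compound 3 (`CC1=NN(c2ccccc2)C(=O)[C@@]12C(=O)C=CC[C@H]2c1cccc(C)c1`) has the same atoms and bonds as compound 2 (the two compounds have the same atoms and bonds and differ only in configuration as drawn: 1 of 2 stereo elements differ; a stereocentre at a saturated ring carbon is drawn S in compound 2 and R in compound 3), and a stereocentre at a saturated ring carbon is drawn S in compound 2 and R in compound 3. Among the measured compounds shown here, no measured pair here isolates a change of this kind, so the data cannot show its size or direction in this assay on their own. For the measured compounds named here, the expectation is no step beyond the scatter, with a slight lean towards lower numbers, and compound 1 at 5210 nM is the only other reading to lean on. The estimated change is a small one, a 1.4-fold lower number from compound 2 to compound 3 (0.14 log units; within the scatter) in size, though a single flipped centre could still prove a surprise. The estimated value for compound 3 is 7000 nM within an expected range of 2500 nM to 20000 nM for now.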

Compound 3, half-maximal inhibitory concentration: 5820 nM
For compound 3 the middle estimate is 1.2-fold (0.08 log units) above the measured one; the range from low to high includes it.
By their numbers in this assay, from the lowest: compounds 1, 3 and 2 (each within the scatter of the next).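

In this assay, the flip of the stereocentre at a saturated ring carbon gives a 1.6-fold lower number from compound 2 to compound 3 (0.22 log units; within the scatter), and this step can be read as the effect of that one centre alone because of a single fact: the fact that compounds 2 and 3 differ only in the configuration as drawn. Compound 3 also separates the two differences that were mixed together between compound 1 and compound 2: 3-methylphenyl in place of 4-methylphenyl on a saturated ring carbon, now as a change on its own, gives a 1.1-fold higher number from compound 1 to compound 3 (0.05 log units; within the scatter). So neither the drawn configuration at this centre nor the choice between these two methylphenyl groups moves the reading beyond the scatter, although this rests on only one pair for each change.

The compounds shown leave open what the second stereo element contributes, as it stays the same between compound 2 and compound 3. They also leave open whether a group of another kind on that phenyl ring, such as an amine or a carboxylic acid in place of the methyl, would move the reading beyond the scatter, and whether the flip would then still make as little difference.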